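Lengthening the chain on compound 2 toward a sulfur-bearing group

The source may hold more compounds than are shown below. What is called first, only, known or untested is meant among the compounds shown, and "the series" means these compounds.

Of the compounds shown here, three have been tested in a functional assay on the whole organism (stomach) for inhibition, with Rattus norvegicus as the target, at a dose of 100 mg/kg by the intraduodenal route; a higher number here means more inhibition at the dose given (going by the name of the read-out), a lower number less inhibition. Compound 1 `CC(Cn1ncccc1=O)C(=N)S` gives 40.3%, compound 3 `C/N=C(\S)C(C)Cn1ncccc1=O` gives 50.2%, and compound 2 `N#CCCn1nc(-c2ccccc2)ccc1=O` gives 10.1%. Compound 2 thus stands lowest of the three, with compound 1 nearest and compound 3 furthest from it, both gaps beyond the scatter.

Compound 4 `N=C(S)CCCCCn1nc(-c2ccccc2)ccc1=O` has not yet been measured. It differs from compound 2 in that (a group of 6 heavy atoms (4 carbon, 1 nitrogen, 1 sulfur; no ring) in place of a group of 2 heavy atoms (1 carbon, 1 nitrogen; no ring), on a saturated chain carbon, two bonds along the chain from an aromatic nitrogen). Among the measured compounds shown here, no measured step repeats this exact change. For the measured compounds named here, the only measured step, a number 9.9 percentage points higher from compound 1 to compound 3 (within the scatter), concerns a different place and a smaller swap, so it says little about compound 4 beyond showing that changes at the sulfur-bearing end move the number only a little. What the numbers do show is that compound 1 and compound 3, which both carry a chain ending in carbon, nitrogen and sulfur, sit far above compound 2, which carries the cyano group. On that basis a rise is expected from compound 2 to compound 4, of about a number 19.9 percentage points higher from compound 2 to compound 4 (beyond the scatter). Compound 4 is therefore estimated at 30%, with a range from 8% to 55%.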

Compound 4, a percentage reported as inhibition, in the whole organism at one dose (the size of the read-out at that dose, not a potency): 91.4%
Compound 4: the middle estimate sits 61.4 percentage points below what was measured; measured number outside the range, above it.
By their numbers in this assay, from the lowest: compound 2; then compounds 1 and 3 (each within the scatter of the next); then compound 4.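

At the saturated chain carbon, two bonds along the chain from an aromatic nitrogen, the read-out in this assay proves highly sensitive: replacing the cyano group with the longer sulfur-bearing group gives a number 81.3 percentage points higher from compound 2 to compound 4 (beyond the scatter). Among the compounds shown here, the only earlier step, a number 9.9 percentage points higher from compound 1 to compound 3 (within the scatter), sits at a different place, so this is the first single change in the set that clearly moves the number. Nothing available explains the size of this step.

This swap alters chain length and end group together, so the two effects cannot be separated: a nitrile on the longer chain of compound 4, or the sulfur-bearing end on a shorter chain, would tell them apart. Going by these compounds, it also remains open whether another end group on this chain, such as an amine or a carboxylic acid, would give a similarly high number.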